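Amide chain extension across two cores

The compounds below may be only part of what the source reports. "The series", "measured", "known", "first", "only" and "open" are said of these compounds alone.

Values below come from an assay on cells for inhibition of cytochrome P450 11B2, mitochondrial (Homo sapiens), read by HTRF; a higher number here means a weaker inhibitor, a lower number a stronger inhibitor.

compound 1 `CCC(=O)N[C@@H]1CCCc2c1cncc2N1C(=O)c2ccc(Cl)cc2[C@@H]1C` gives 6 nM
compound 2 `CCC(=O)N[C@@H]1CCCc2c1cncc2N1C(=O)c2ccc(Cl)cc2[C@@H]1CC` gives 12 nM
compound 3 `CC(=O)N[C@@H]1CCCc2c1cncc2N1Cc2cc(Cl)ccc2C1=O` gives 44 nM

Compound 1 and compound 2 share one core; compound 3 and the unmeasured compound 4 `CCC(=O)N[C@@H]1CCCc2c1cncc2N1Cc2cc(Cl)ccc2C1=O` share another. The difference between the two cores is not broken down here. Compound 3 gives the highest number of the three measured.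

From compound 1 to compound 2 the change is methyl in place of hydrogen on a saturated chain carbon bound to a saturated ring carbon, and the step is a 2.0-fold higher number from compound 1 to compound 2 (0.30 log units; within the scatter). The change from compound 3 to compound 4 is methyl in place of hydrogen on a saturated chain carbon bound to a carbonyl carbon. The place is not the same: in the first case the saturated chain carbon is bound to a saturated ring carbon, in the second to a carbonyl carbon, so this is the same kind of change, not the same change.

For compound 4 the expected step is a 1.3-fold lower number from compound 3 to compound 4 (0.10 log units; within the scatter), set beside the earlier methyl-for-hydrogen step because a 2.0-fold higher number from compound 1 to compound 2 (0.30 log units; within the scatter) stayed within the scatter. Compound 4 is therefore estimated at 35 nM, with a range from 12 nM to 100 nM.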

Compound 4, half-maximal inhibitory concentration: 28 nM
Compound 4: middle estimate off by 1.3-fold (0.10 log units), on the high side, and the stated range covers the measured number.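

In this assay, methyl in place of hydrogen on a saturated chain carbon bound to a carbonyl carbon gives a 1.6-fold lower number from compound 3 to compound 4 (0.20 log units; within the scatter), and this does not match the earlier case, where the same kind of change sat on a saturated chain carbon bound to a saturated ring carbon: the same change on two cores in this assay, a 2.0-fold higher number (0.30 log units; within the scatter) from compound 1 to compound 2 and a 1.6-fold lower number (0.20 log units; within the scatter) from compound 3 to compound 4, 3.1-fold (0.50 log units) apart, beyond the scatter of two such steps
Each step alone lies within the scatter, so this shows a gap between two single pairs, not a cause or a rule for other cores. Hydrogen in place of methyl on a saturated ring carbon gives a 4.7-fold higher number from compound 1 to compound 4 (0.67 log units; beyond the scatter), and hydrogen in place of ethyl there gives a 2.3-fold higher number from compound 2 to compound 4 (0.37 log units; beyond the scatter), both beyond the scatter.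

Still open, going by these compounds, is how a longer chain than propanoyl on the amide would behave. Also open, on these data alone, is what a cyclopropyl group or an amine on that saturated ring carbon would do.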